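Swapping a ring substituent in a weakly cytotoxic curcumin-like series

The source may report more compounds than this note shows. Statements on the series, on what has been measured and on what is new or still open speak of the compounds shown alone.

Measured compounds:
compound 1, `COc1cc(/C=C/C(=O)C2=C(/C=C/c3ccc(O)c(OC)c3)NC(=O)NC2c2ccc(C)cc2)ccc1O`: 100000 nM
compound 2, `COc1cc(/C=C/C(=O)C2=C(/C=C/c3ccc(O)c(OC)c3)NC(=O)NC2c2ccccc2O)ccc1O`: 50000 nM

In a functional assay on HeLa cells (Homo sapiens) for cytotoxicity, read by MTT assay, with a stated time of 48 h (on this read-out lower numbers stand for stronger inhibition and higher numbers for weaker inhibition), compound 1 gives 100000 nM, the highest of the two numbers recorded; its nearest neighbour is compound 2, which in this assay gives 50000 nM. Among the measured compounds shown here, the one step between them, a 2.0-fold lower number from compound 1 to compound 2 (0.30 log units; within the scatter), replaces 4-methylphenyl with 2-hydroxyphenyl on a saturated ring carbon and stays within the scatter.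

Compound 3, `COc1cc(/C=C/C(=O)C2=C(/C=C/c3ccc(O)c(OC)c3)NC(=O)NC2c2ccc(N(C)C)cc2)ccc1O`, has not yet been measured. Relative to compound 1 the change is dimethylamino in place of methyl on an aromatic carbon; cut one bond further out, it reads 4-methylphenyl to 4-(dimethylamino)phenyl, the new group sitting on an aromatic carbon of a six-membered aromatic ring of carbon only, para to a large group.

For the measured compounds named here, no measured step touches this position directly. Going by the values given here, the only comparison available, a 2.0-fold lower number from compound 1 to compound 2 (0.30 log units; within the scatter), shows that even exchanging the whole aryl group on the saturated ring carbon moved the number by less than the scatter. A step of similar size is therefore expected for compound 3, a 1.4-fold lower number from compound 1 to compound 3 (0.15 log units; within the scatter), with no clear direction. Compound 3 is accordingly estimated at 70000 nM, within 25000 nM to 150000 nM.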

Compound 3, half-maximal inhibitory concentration: 25000 nM
Estimate against measurement, compound 3: 2.8-fold (0.45 log units) above, and the stated range covers the measured number.
By their numbers in this assay, from the lowest: compounds 3, 2 and 1 (each within the scatter of the next, the first and the last beyond it).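

In this assay, the aromatic carbon para to a large group proves able to move the number: dimethylamino in place of methyl gives a 4.0-fold lower number from compound 1 to compound 3 (0.60 log units; beyond the scatter), the only step among these compounds that is printed as beyond the scatter, though it is modest. The other new step, 4-(dimethylamino)phenyl in place of 2-hydroxyphenyl on a saturated ring carbon, gives a 2.0-fold lower number from compound 2 to compound 3 (0.30 log units; within the scatter), so compound 3 cannot be told apart from compound 2, and its separation from compound 1 is the only clear difference in the set. No measurement shown here bears on why this change shifts the number.

The compounds shown leave open whether a primary amine or a carboxylic acid on the same aromatic carbon would move the number as dimethylamino does, and whether longer chains on the nitrogen, such as diethylamino, would take it further. With a single amine at this place, they also leave open whether the step reflects a trend, and whether it would hold outside these HeLa cells.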